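The source may hold more compounds than are shown below. What is called first, only, known or untested is meant among the compounds shown, and "the series" means these compounds.

Measured in a physicochemical assay for solubility, in phosphate buffer, with a stated time of 18 h; on this read-out lower numbers stand for lower solubility and higher numbers for higher solubility:

- compound 1 `CC(C)(C)c1nc(-c2ccc[nH]2)c2cc(C(N)=O)c(N)nc2n1`: 130000 nM
- compound 2 `CC(C)Cc1ncc2c(N)c(C#N)c(N)nc2n1`: 268000 nM
- compound 3 `CSc1nc(C(C)(C)C)nc2nc(N)c(C#N)c(N)c12`: 14000 nM

Compound 3 stands lowest of the three numbers in this assay; its nearest neighbour is compound 1, whose number is higher by a margin beyond the scatter, and compound 2 lies further still, also beyond the scatter. For the measured compounds named here, no single-point step between measured compounds is available, so the three values can only be read side by side.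

Compound 4 `CC(C)(C)c1nc(-c2ccccc2)c2c(N)c(C#N)c(N)nc2n1` is the next compound to be measured. Relative to compound 3 it differs in one place: phenyl in place of methylsulfanyl on an aromatic carbon. The change puts phenyl, with its six-membered aromatic ring of carbon only, where the two-heavy-atom methylsulfanyl stood on the aromatic carbon of the shared core.

With no measured step of this kind in the series, the expected step of a 1.6-fold lower number from compound 3 to compound 4 (0.19 log units; within the scatter) is a modest decrease, within or just beyond the scatter. Compound 4 is therefore estimated at 9000 nM, with a range from 2500 nM to 35000 nM.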

Compound 4, solubility: 4000 nM
Beside the measured number, compound 4's estimate is 2.3-fold (0.35 log units) above it; measured number inside the range.
By their numbers in this assay, from the lowest: compound 4; then compound 3; then compound 1; then compound 2.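

Replacing methylsulfanyl with phenyl on the aromatic carbon next to the ring nitrogen gives the series its first one-place comparison in this assay: a 3.5-fold lower number from compound 3 to compound 4 (0.54 log units; beyond the scatter). The number at this position therefore depends on the group it carries, and the larger aromatic group gives the lower number in this one pair. The step swaps a sulfur-containing group without a ring for a six-membered aromatic ring of carbon only, but no measurement on hand accounts for the change.

A single pair cannot separate the effect of adding the ring from that of losing methylsulfanyl. An amine, a methoxy group or a pyridine ring at this position would show whether the number depends on the ring itself or on its atoms.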